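4-Nitrophenyl to 4-chlorophenyl: a step expected within scatter

The source may report more compounds than this note shows. Statements on the series, on what has been measured and on what is new or still open speak of the compounds shown alone.

In a functional assay on microsomes from liver (Rattus norvegicus, strain Wistar) for inhibition, with a stated time of 15 min (on this read-out higher numbers stand for weaker inhibition and lower numbers for stronger inhibition), compound 1 `COc1cc(C2CC(c3cc4ccccc4o3)=NN2C(=O)Nc2cccc(O)c2)ccc1O` gives 24000000 nM, compound 2 `COc1cc(C2CC(c3cc4ccccc4o3)=NN2C(=O)Nc2ccc(F)cc2)ccc1O` gives 125000000 nM and compound 3 `COc1cc(C2CC(c3cc4ccccc4o3)=NN2C(=O)Nc2ccc([N+](=O)[O-])cc2)ccc1O` gives 113000000 nM. Compound 3 therefore stands level with compound 2, within the scatter, and carries a clearly higher number than compound 1. Compound 4 `COc1cc(C2CC(c3cc4ccccc4o3)=NN2C(=O)Nc2ccc(Cl)cc2)ccc1O` has chloro in place of nitro on an aromatic carbon, para to a large group: chloro in place of nitro on an aromatic carbon.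

The nearest measured change is a 1.1-fold lower number from compound 2 to compound 3 (0.04 log units; within the scatter), nitro in place of fluoro, which lies within the scatter. Larger steps appear only where 3-hydroxyphenyl is replaced: a 5.2-fold higher number from compound 1 to compound 2 (0.72 log units; beyond the scatter) and a 4.7-fold higher number from compound 1 to compound 3 (0.67 log units; beyond the scatter), both modest and beyond the scatter. That replacement plays no part in the present change, so no step beyond the scatter is expected in this assay. The estimated change is a 1.1-fold lower number from compound 3 to compound 4 (0.05 log units; within the scatter), with no firm direction expected. For compound 4 the expected value is 100000000 nM, with an estimated range from 45000000 nM to 200000000 nM.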

Compound 4, half-maximal inhibitory concentration: 121000000 nM
The estimate for compound 4 lay 1.2-fold (0.08 log units) below the measured number; low and high end bracket the measured number.
By their numbers in this assay, from the lowest: compound 1; then compounds 3, 4 and 2 (each within the scatter of the next).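

In this assay, among the compounds shown here, chloro in place of nitro on an aromatic carbon, para to a large group, gives a 1.1-fold higher number from compound 3 to compound 4 (0.03 log units; within the scatter), and chloro in place of fluoro gives a 1.0-fold lower number from compound 2 to compound 4 (0.01 log units; within the scatter), so chloro, fluoro and nitro now stand level within the scatter, and the loss of the nitro group's hydrogen-bond acceptors leaves no step that can be read. The gap to the 3-hydroxyphenyl compound also holds with this third group, at a 5.0-fold higher number from compound 1 to compound 4 (0.70 log units; beyond the scatter), so compound 1 stays apart from compounds 2, 3 and 4. No evidence bearing on the result is available to explain this flat response.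

From the compounds shown here alone, whether an amine or a carboxylic acid in place of chloro would stay level with these three groups remains open. For the compounds shown here, it is also open whether the hydroxyl alone separates compound 1, since the 3-hydroxyphenyl group has no close counterpart here.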